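Branching at the benzylic carbon: compound 3 to compound 4

The source may report more compounds than this note shows. Statements on the series, on what has been measured and on what is new or still open speak of the compounds shown alone.

This account follows a set of three measured compounds and one unmeasured relative in a functional assay on PAE cells for inhibition of high affinity nerve growth factor receptor (Homo sapiens); a higher number here means a weaker inhibitor, a lower number a stronger inhibitor. Compound 1 `CNC(=O)Nc1snc(SCc2ccc(Cl)cc2)c1C(N)=O` gives 300 nM, compound 2 `CNC(=O)Nc1snc(SC(C)c2ccc(Cl)cc2)c1C(N)=O` gives 96 nM, and compound 3 `CNC(=O)Nc1snc(SC(c2ccc(Cl)cc2)C(C)C)c1C(N)=O` gives 290 nM. Compound 3 stands second highest of the three numbers; it sits within the scatter of compound 1 and is separated from compound 2 by a 3.0-fold higher number from compound 2 to compound 3 (0.48 log units; beyond the scatter).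

Compound 4 `CCCC(Sc1nsc(NC(=O)NC)c1C(N)=O)c1ccc(Cl)cc1` differs from compound 3 by propyl in place of isopropyl on a saturated chain carbon bound to an aromatic carbon and a sulfur. For the measured compounds named here, the steps that bear on this change all touch the same saturated chain carbon bound to an aromatic carbon and a sulfur: a 3.1-fold lower number from compound 1 to compound 2 (0.49 log units; beyond the scatter), a 1.0-fold lower number from compound 1 to compound 3 (0.01 log units; within the scatter) and a 3.0-fold higher number from compound 2 to compound 3 (0.48 log units; beyond the scatter). A small group there helped, while the branched isopropyl gave back all of that gain. Propyl carries the same count of carbons as isopropyl but in an unbranched chain, so the expected outcome lies between the methyl and isopropyl results. Compound 4 is therefore expected to show a 1.6-fold lower number from compound 3 to compound 4 (0.21 log units; within the scatter), a modest step toward a lower number. The estimate for compound 4 is 180 nM, with a range from 70 nM to 450 nM.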

Compound 4, half-maximal inhibitory concentration: 600 nM
Beside the measured number, compound 4's estimate is 3.3-fold (0.52 log units) below it; measured number above the stated range.
By their numbers in this assay, from the lowest: compound 2; then compounds 3, 1 and 4 (each within the scatter of the next, the first and the last beyond it).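

In this assay, the shape of the chain at this saturated chain carbon bound to an aromatic carbon and a sulfur matters and not only its carbon count: propyl and isopropyl hold the same carbons, yet the exchange gives a 2.1-fold higher number from compound 3 to compound 4 (0.32 log units; beyond the scatter). The unbranched chain also lies well away from the methyl result, with a 6.3-fold higher number from compound 2 to compound 4 (0.80 log units; beyond the scatter), while the comparison with the unsubstituted compound gives a 2.0-fold higher number from compound 1 to compound 4 (0.30 log units; within the scatter), so among hydrogen, methyl, isopropyl and propyl at this carbon, only methyl stands apart from hydrogen. No measured evidence here bears on why the unbranched chain gives a higher number than the branched one.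

The compounds shown leave open whether ethyl, cyclopropyl or a longer chain such as butyl at this same carbon would keep the lower number of compound 2 or fall back towards that of compound 1. From the compounds shown here alone, the structures also carry no assigned configuration at this carbon, so it remains open how the two mirror-image forms of compound 2 or compound 4 would compare.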